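The source may report more compounds than this note shows. Statements on the series, on what has been measured and on what is new or still open speak of the compounds shown alone.

Measured so far in a physicochemical assay for solubility, in phosphate buffer, measured as kinetic solubility, with a stated time of 1 h, at pH 7.4 (a higher number here means a more soluble compound, a lower number a less soluble compound), are three compounds:
- compound 1 `CCNC(=O)Nc1ccc(-c2nccc([C@]34CCOC[C@H]3C4)n2)cc1` gives 125 ug/mL here
- compound 2 `Oc1cccc(-c2nccc([C@]34CCOC[C@H]3C4)n2)c1` gives 141 ug/mL here
- compound 3 `Oc1cccc(-c2nccc(C3=CCOCC3)n2)c1` gives 113 ug/mL here

The three numbers lie within the usual scatter of one another, so compound 1, at 125 ug/mL in this set, cannot be separated from either neighbour. The set is small, and no two of its members make a step that differs in one place.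

The step followed here leads to compound 4 `CCNC(=O)Nc1ccc(-c2nc(C(C)(C)S(C)(=O)=O)cc([C@]34CCOC[C@H]3C4)n2)cc1`, which has not yet been measured. It keeps the core of compound 1 and carries 1-methyl-1-(methylsulfonyl)ethyl in place of hydrogen on an aromatic carbon of the six-membered aromatic ring with 2 nitrogen. Among the measured compounds shown here, none of the measured compounds carries this group, so the data offer no comparable step to borrow. The expectation in this assay is therefore a judgement that starts from compound 1 at 125 ug/mL and not a trend read from the set. A downward step of moderate size, somewhat beyond the scatter, is expected, and the estimated change is a 2.3-fold lower number from compound 1 to compound 4 (0.36 log units; beyond the scatter) as a central figure. The estimate for compound 4 is 55 ug/mL as a middle value, with an expected range from 15 ug/mL to 130 ug/mL around it.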

Compound 4, solubility: 74 ug/mL
Estimate against measurement, compound 4: 1.3-fold (0.13 log units) below; the measured number falls inside the stated range.
By their numbers in this assay, from the lowest: compounds 4, 3, 1 and 2 (each within the scatter of the next).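

Among the compounds shown here, the step from compound 1 to compound 4 is the first in this set that changes only one place, and it gives the set its first direct reading of this position in this assay. Putting 1-methyl-1-(methylsulfonyl)ethyl in place of hydrogen on an aromatic carbon of the six-membered aromatic ring with 2 nitrogen, next to the ring nitrogen, gives a 1.7-fold lower number from compound 1 to compound 4 (0.23 log units; within the scatter), so this group of 7 heavy atoms leaves the two compounds inseparable in this read-out. Nothing offered here accounts for the numbers or says what lies behind them.

This single step leaves open whether a smaller group at the same carbon, such as methyl, or a group of another kind, such as a dimethylamino group or a carboxylic acid, would also stay within the scatter of compound 1. It also leaves open whether 1-methyl-1-(methylsulfonyl)ethyl would give a similar reading at the same place on compound 2 or compound 3, which carry a different substitution on the shared ring system.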